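The source may hold more compounds than are shown below. What is called first, only, known or untested is meant among the compounds shown, and "the series" means these compounds.

Measured so far in a functional assay on HOS-TE85 cells (Homo sapiens) for inhibition, read by CCK-8 assay, with a stated time of 72 h, tested at 1 uM; a lower number here means less inhibition, a higher number more inhibition at the concentration tested (going by the name of the read-out):
compound 1 `COc1ccc(C)cc1N1C(=O)CSC1c1cccc(C(=O)NCCCCc2ccccc2)c1` gives 95%
compound 2 `COc1cccc(OC)c1N1C(=O)CSC1c1cccc(C(=O)NCCCCc2ccccc2)c1` gives 95%

Compound 2 stands level with compound 1 at the digits shown. Among the measured compounds shown here, the only measured step is no change at the digits printed from compound 1 to compound 2 (within the scatter), an exchange of one aryl group for another on the ring nitrogen that left the read-out within the scatter. Compound 3 `CC(F)(F)c1cccc(N2C(=O)CSC2c2cccc(C(=O)NCCCCc3ccccc3)c2)c1` carries the change (a group of 10 heavy atoms (8 carbon, 2 fluorine; one six-membered aromatic ring of carbon only) in place of a group of 10 heavy atoms (8 carbon, 2 oxygen; one six-membered aromatic ring of carbon only), on an amide-type nitrogen in a ring). The step from compound 1 to compound 2 is the one that bears on this: it is an exchange of the same kind, at the same place, and it was flat. For the measured compounds named here, the group entering here carries fluorine in place of oxygen, and no measured step covers such a group, so the range is widened toward lower values. The expected step is about a number 4 percentage points lower from compound 2 to compound 3 (within the scatter) in this assay, none beyond the scatter. Compound 3 is estimated at 91%, with a range from 75% to 98%.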

Compound 3, a percentage reported as inhibition, at one concentration (the size of the read-out at that concentration, not a potency): 93%
Compound 3: middle estimate off by 2 percentage points, on the low side; measured number inside the range.
By their numbers in this assay, from the lowest: compounds 3, 1 and 2 (each within the scatter of the next).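

In this assay, placing the group of 8 carbon and 2 fluorine on the amide-type nitrogen gives a number 2 percentage points lower from compound 2 to compound 3 (within the scatter), and a number 2 percentage points lower from compound 1 to compound 3 (within the scatter). Both groups it replaces carry oxygen, whereas the entering group has 0 hydrogen-bond acceptors, so methoxy oxygen on this aryl group is not required to keep the read-out of this assay within the scatter across compounds 1, 2 and 3. No supporting measurement bears on why this exchange leaves the read-out flat.

All three values lie close together at a single concentration, so any potency differences among these compounds remain unresolved. As far as these compounds go, it remains open whether a carboxylic acid or an amine on this aryl ring would shift the read-out, and whether a shorter chain in place of the four-carbon linker in the phenylbutyl amide would do so.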